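The compounds below may be only part of what the source reports. "The series", "measured", "known", "first", "only" and "open" are said of these compounds alone.

Three compounds share one core and differ only in the aromatic group attached to it. Compound 1 `c1ccc2c(-c3cn4ccnc4c(-c4ccc5ncn(C6CCCCC6)c5c4)n3)cccc2c1` carries a naphthalen-1-yl group there, and in a functional assay on MDA-MB-231 cells (Homo sapiens) for inhibition, read by sulforhodamine B assay, with a stated time of 48 h, tested at 10 uM (on this read-out lower numbers stand for less inhibition and higher numbers for more inhibition at the one concentration tested (going by the name of the read-out)), compound 1 gives 20.8%. Compound 2 `Clc1ccc(-c2cn3ccnc3c(-c3ccc4ncn(C5CCCCC5)c4c3)n2)cc1` carries a 4-chlorophenyl group, and compound 2 gives 15.3%. Compound 3 `COc1ccccc1-c1cn2ccnc2c(-c2ccc3ncn(C4CCCCC4)c3c2)n1` carries a 2-methoxyphenyl group, and compound 3 gives 15.9%. The three values sit close together: the change is a number 5.5 percentage points lower from compound 1 to compound 2 (within the scatter), then a number 4.9 percentage points lower from compound 1 to compound 3 (within the scatter), and between the two phenyl compounds a number 0.6 percentage points higher from compound 2 to compound 3 (within the scatter). On these numbers compound 3 stands second highest of the three, with compound 2 nearest and compound 1 furthest, both within the scatter.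

Compound 4 `Fc1ccccc1-c1cn2ccnc2c(-c2ccc3ncn(C4CCCCC4)c3c2)n1` is the next member. Relative to compound 3 the difference is fluoro in place of methoxy on an aromatic carbon. Among the compounds with values here, the steps that bear on it are those exchanging one aromatic group for another on the same carbon, and all three of them stayed within the scatter. An exchange of a methoxy for a fluoro on the same ring is therefore expected to give a step of a number 0.1 percentage points higher from compound 3 to compound 4 (within the scatter), that is, none beyond the scatter. Compound 4 is thus estimated at 16%, within a range of 7% to 27%.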

Compound 4, a percentage reported as inhibition, at one concentration (the size of the read-out at that concentration, not a potency): 21.3%
For compound 4 the middle estimate is 5.3 percentage points below the measured one, and the stated range covers the measured number.
By their numbers in this assay, from the lowest: compounds 2, 3, 1 and 4 (each within the scatter of the next).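

In this assay, within the data shown here, the exchange on the aromatic carbon ortho to a large group, 2-methoxyphenyl to 2-fluorophenyl, gives a number 5.4 percentage points higher from compound 3 to compound 4 (within the scatter), and this is the first step that keeps the substituent at that place on the phenyl ring and changes only the substituent itself. Compound 4 also stays within the scatter of the other two compounds, with a number 6 percentage points higher from compound 2 to compound 4 (within the scatter) and a number 0.5 percentage points higher from compound 1 to compound 4 (within the scatter). Among these compounds, the position therefore now holds four different aromatic groups, including two ortho-substituted phenyl rings with a one-atom fluoro or a two-atom methoxy, and no step among the four compounds lies beyond the scatter, so this read-out separates none of them.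

On these data alone, whether a primary amine, a carboxylic acid or a longer alkoxy chain in place of the fluoro on this ring would give a step beyond the scatter remains open, as does the same exchange at another place on the ring. Nothing available explains the values of these four compounds or accounts for the small differences among them.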